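From cyclohexyl to phenyl: an expected small step

This account rests on a few compounds, and the source may have more. Where it says the series, first, only, none or still open, it means among the compounds named here.

Two compounds have numbers in a functional assay on MCF7 cells (Homo sapiens) for inhibition, read by sulforhodamine B assay, with a stated time of 48 h (a lower number here means a stronger inhibitor of growth, a higher number a weaker inhibitor of growth), so far. Compound 1 (`c1ccc(COc2ccc(NC3=NCCO3)cc2)cc1`) gives 11100 nM in this test. Compound 2 (`O=C(CCl)NC(=O)Nc1ccc(C2CCCCC2)cc1`) gives 1500 nM and holds the lowest of the two numbers, with a gap to compound 1 that lies beyond the usual scatter. Compound 3 (`O=C(CCl)NC(=O)Nc1ccc(-c2ccccc2)cc1`) has not yet been measured. It differs from compound 2 by phenyl in place of cyclohexyl on an aromatic carbon. Among the compounds with values here, no two measured compounds differ in one place, so the data offer no direct guide to this exchange. The estimate therefore rests on compound 2 at 1500 nM as its anchor. The expected step of a 1.7-fold higher number from compound 2 to compound 3 (0.22 log units; within the scatter) is a small rise in the number, probably within the scatter. Compound 3 is estimated at 2500 nM with a range from 900 nM to 7000 nM in this expectation.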

Compound 3, concentration for 50% growth inhibition: 3900 nM
Estimate against measurement, compound 3: 1.6-fold (0.19 log units) below; the range from low to high includes it.
By their numbers in this assay, from the lowest: compound 2; then compound 3; then compound 1.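

In this assay, within the data shown here, phenyl in place of cyclohexyl on an aromatic carbon, para to a group of 8 heavy atoms, gives a 2.6-fold higher number from compound 2 to compound 3 (0.41 log units; beyond the scatter), the first step in this set that can be read at a single place. The two groups have the same count of heavy atoms and neither has hydrogen-bond donors or acceptors, so the exchange turns a non-aromatic ring into an aromatic one, and the modest rise in the number lies beyond the usual scatter. Nothing given here accounts for the size of this step.

Going by these compounds, it remains open where an open-chain group such as tert-butyl, or an amine, would fall at this place relative to compound 2 and compound 3. On these data alone, a smaller ring such as cyclopentyl is equally open.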